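What a 4-Fluorobenzyl Group May Do to Compound 3

The compounds below may be only part of what the source reports. "The series", "measured", "known", "first", "only" and "open" are said of these compounds alone.

Three measured compounds share one core and differ only in the group on a carbonyl carbon. Compound 1 `CC[C@@H](C)[C@H](NC(=O)c1ccc(C(CC)(CC)c2ccc(OCC(=O)C(C)(C)C)c(C)c2)n1CC)C(=O)OC` carries (1-(methoxycarbonyl)-2-methylbutyl)amino there, compound 2 `C#CCCOC(=O)c1ccc(C(CC)(CC)c2ccc(OCC(=O)C(C)(C)C)c(C)c2)n1CC` carries (but-3-yn-1-yl)oxy, and compound 3 `CCn1c(C(=O)N(C)CC(=O)O)ccc1C(CC)(CC)c1ccc(OCC(=O)C(C)(C)C)c(C)c1` carries (carboxymethyl)(methyl)amino. In an assay on HL-60 cells for agonist activity at vitamin D3 receptor (Homo sapiens), read by microscopy, with a stated time of 96 h (on this read-out higher numbers stand for an effect only at larger amounts of compound and lower numbers for an effect already at smaller amounts), compound 1 gives 590 nM, compound 2 gives 28800 nM, and compound 3 gives 1390 nM. Compound 3 therefore holds the second highest of the three numbers: the step of a 2.4-fold higher number from compound 1 to compound 3 (0.37 log units; beyond the scatter) is modest, whereas the step of a 21-fold lower number from compound 2 to compound 3 (1.32 log units; beyond the scatter) is large.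

Compound 4 `CCn1c(C(=O)OCc2ccc(F)cc2)ccc1C(CC)(CC)c1ccc(OCC(=O)C(C)(C)C)c(C)c1` awaits measurement. It differs from compound 3 by (4-fluorobenzyl)oxy in place of (carboxymethyl)(methyl)amino on a carbonyl carbon. Within the data shown here, no measured pair shows this exact exchange, but two steps bear on it. The step of a 49-fold higher number from compound 1 to compound 2 (1.69 log units; beyond the scatter) and the step of a 21-fold lower number from compound 2 to compound 3 (1.32 log units; beyond the scatter) both place the compound with (but-3-yn-1-yl)oxy on that carbonyl carbon far above either compound with an amino group there. Compound 4 again carries an oxy group at that position, so a large rise in this assay is expected, with an 11-fold higher number from compound 3 to compound 4 (1.03 log units; beyond the scatter) as the estimated step. Compound 4 is accordingly expected to give about 15000 nM, within a range from 4000 nM to 60000 nM.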

Compound 4, half-maximal effective concentration: 9500 nM
Estimate against measurement, compound 4: 1.6-fold (0.20 log units) above; the measured number falls inside the stated range.
By their numbers in this assay, from the lowest: compound 1; then compound 3; then compound 4; then compound 2.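

Compound 4 gives this position a second oxy group, and in this assay the change from an amino group again moves the compound towards needing larger amounts, with a 6.8-fold higher number from compound 3 to compound 4 (0.83 log units; beyond the scatter) and a 16-fold higher number from compound 1 to compound 4 (1.21 log units; beyond the scatter) as the two steps. All four compounds now fit one pattern, with none going against it: both compounds with an oxy group on the carbonyl carbon have higher numbers than both with an amino group there. Among these compounds, the oxy compounds are not interchangeable, however, as a 3.0-fold lower number from compound 2 to compound 4 (0.48 log units; beyond the scatter) shows that what is attached beyond the oxygen also changes the number, although that step is smaller than the one separating compound 1 from compound 4.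

The data shown offer no measured explanation for these differences. From the compounds shown here alone, whether the fluorine in the (4-fluorobenzyl)oxy group matters remains open, as does the place on this scale of a benzyloxy group without fluorine, a simple methoxy group, or a longer chain on the oxygen.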